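Phenyl for methylcyclopropyl on the carbamate oxygen

This account rests on a few compounds, and the source may have more. Where it says the series, first, only, none or still open, it means among the compounds named here.

compound 1 `CC(C)(C)OC(=O)N1CCC(O[C@H]2CC[C@@H](Oc3ccc(S(C)(=O)=O)cc3)CC2)CC1`: 121%
compound 2 `CC(C)(C)OC(=O)N1CCC(O[C@H]2CC[C@H](Oc3ccc(S(C)(=O)=O)cc3)CC2)CC1`: 120%
compound 3 `CC1(OC(=O)N2CCC(O[C@H]3CC[C@H](Oc4cnc(S(C)(=O)=O)cn4)CC3)CC2)CC1`: 123%

Of the compounds shown here, three have been measured in a functional assay on isolated protein for agonist activity at Glucose-dependent insulinotropic receptor (Rattus norvegicus), read by HTRF and cAMP accumulation; a higher number here means a larger maximal response, a lower number a smaller maximal response. Compound 1 gives 121% in this assay. Compound 2 is its mirror image, and the step of a number 1 percentage points lower from compound 1 to compound 2 (within the scatter) is what one sees on inverting all stereocentres; the two compounds are otherwise identical because of the fact that compounds 1 and 2 differ only in the configuration as drawn. Compound 3 carries a different aromatic ring and a 1-methylcyclopropyl ester, and in this assay compound 3 gives 123%. This is the highest of the three numbers, but its nearest neighbour is compound 1 and its furthest is compound 2, both within the scatter, so the three compounds cannot be ranked.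

Compound 4 `CS(=O)(=O)c1cnc(O[C@H]2CC[C@H](OC3CCN(C(=O)Oc4ccccc4)CC3)CC2)cn1` has not yet been measured. It differs from compound 3 by phenyl in place of 1-methylcyclopropyl on an oxygen next to a carbonyl group. For the measured compounds named here, no measured step touches this part of the molecule; the only measured step, a number 1 percentage points lower from compound 1 to compound 2 (within the scatter), concerns configuration and lies within the scatter. Going by the values given here, with no measured precedent for the change, the step of a number 3 percentage points lower from compound 3 to compound 4 (within the scatter) is expected to be small, with no direction beyond the scatter. The estimate for compound 4 is 120%, between 105% and 135%.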

Compound 4, largest response reached (Emax), in percent of the reference or control that the assay uses: 104%
For compound 4 the middle estimate is 16 percentage points above the measured one, outside the stated range (below it).
By their numbers in this assay, from the lowest: compound 4; then compounds 2, 1 and 3 (each within the scatter of the next).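

In this assay, the group on the oxygen next to the carbonyl group proves to matter: phenyl in place of 1-methylcyclopropyl gives a number 19 percentage points lower from compound 3 to compound 4 (beyond the scatter) and is the only step among the compounds shown that exceeds the scatter. The maximal response therefore does not stay the same whatever group sits at this place, as the close values of the first three compounds might have suggested, although those compounds never isolated this change. The single available fact concerns configuration, so nothing at hand accounts for this step.

The compounds shown leave open whether the lower response goes with the aromatic ring of phenyl or with the change from a group of four heavy atoms to one of six, and cyclohexyl or benzyl on the same oxygen would bear on that question. On these data alone, it also remains open whether the same exchange would give a step of similar size on the core of compound 1, which carries a different aromatic ring from compound 3.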